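The compounds below may be only part of what the source reports. "The series", "measured", "known", "first", "only" and "open" are said of these compounds alone.

Measured so far in a functional assay on SGC-7901 cells (Homo sapiens) for cytotoxicity, read by MTT assay, with a stated time of 48 h; a lower number here means a stronger inhibitor, a higher number a weaker inhibitor:
Compound 1 `CCN(CC)c1ccc2cc(C(=O)c3ccc(N4CCN(C(=O)CN5CCN(S(=O)(=O)C6CC6)CC5)CC4)cc3)oc2c1` gives 15300 nM in this assay.
Compound 2 `CCN(CC)c1ccc2cc(C(=O)c3ccc(N4CCN(C(=O)CN5CCN(S(=O)(=O)c6ccc(OC(F)(F)F)cc6)CC5)CC4)cc3)oc2c1` gives 24400 nM in this assay.
Compound 3 `CCN(CC)c1ccc2cc(C(=O)c3ccc(N4CCN(C(=O)CN5CCN(Cc6ccc(F)c(F)c6)CC5)CC4)cc3)oc2c1` gives 1780 nM in this assay.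

Among these three numbers, compound 1 stands second highest. Its nearest neighbour is compound 2, and a 1.6-fold higher number from compound 1 to compound 2 (0.20 log units; within the scatter) lies within the scatter, so the two cannot be told apart; the exchange there is 4-(trifluoromethoxy)phenyl in place of cyclopropyl on the sulfonyl sulfur. Its furthest neighbour is compound 3, and an 8.6-fold lower number from compound 1 to compound 3 (0.93 log units; beyond the scatter) lies beyond the scatter.

Compound 4 `CCN(CC)c1ccc2cc(C(=O)c3ccc(N4CCN(C(=O)CN5CCN(Cc6ccc(C(F)(F)F)cc6)CC5)CC4)cc3)oc2c1` has not yet been measured in this assay. Compared with compound 1 it carries 4-(trifluoromethyl)benzyl in place of cyclopropylsulfonyl on an amine nitrogen in a ring. Within the data shown here, the step that bears on this is the one to compound 3, where the same cyclopropylsulfonyl left the same ring nitrogen and a 3,4-difluorobenzyl entered, giving an 8.6-fold lower number from compound 1 to compound 3 (0.93 log units; beyond the scatter). Compound 4 differs from compound 3 only in the substituent pattern of the benzyl group, so a step of similar size and the same direction is expected. For compound 4 the expected step is a 6.1-fold lower number from compound 1 to compound 4 (0.79 log units; beyond the scatter). The value of compound 4 in this assay is therefore estimated at 2500 nM, with a likely range from 900 nM to 7000 nM.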

Compound 4, half-maximal inhibitory concentration: 32000 nM
The estimate for compound 4 lay 13-fold (1.11 log units) below the measured number; measured number above the stated range.
By their numbers in this assay, from the lowest: compound 3; then compounds 1, 2 and 4 (each within the scatter of the next, the first and the last beyond it).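

In this assay a benzyl group on this amine nitrogen does not in itself bring a lower number: 4-(trifluoromethyl)benzyl in place of cyclopropylsulfonyl gives a 2.1-fold higher number from compound 1 to compound 4 (0.32 log units; beyond the scatter) and so runs opposite to the step to compound 3. What separates the two benzyl compounds is only the substitution on the aromatic ring, and 4-(trifluoromethyl)phenyl in place of 3,4-difluorophenyl gives an 18-fold higher number from compound 3 to compound 4 (1.25 log units; beyond the scatter) in what is the largest step in this set. No measurement at hand accounts for this gap.

The compounds shown leave open whether an unsubstituted benzyl group on this nitrogen would stand nearer compound 3 or compound 4. They also leave open what a single fluorine or a methoxy group on the benzyl ring would give.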